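The source may report more compounds than this note shows. Statements on the series, on what has been measured and on what is new or still open speak of the compounds shown alone.

Measured compounds:
Compound 1 `Clc1ccc2c(NCCCNc3ccnc(N4CCCCC4)n3)ccnc2c1` gives 320 nM in a physicochemical assay for solubility, read by HPLC, in phosphate buffer, with a stated time of 24 h, at pH 7.4; a lower number here means a less soluble compound, a higher number a more soluble compound.
Compound 2 `Clc1ccc2c(NCCCCCCCCNc3nccc(Cl)n3)ccnc2c1` gives 90 nM in this assay.
Compound 3 `Clc1ccc2c(NCCCNc3nccc(N4CCNCC4)n3)ccnc2c1` gives 600 nM in this assay.

Compound 2 stands lowest of the three numbers. Its nearest neighbour is compound 1, whose value is higher by an amount beyond the usual scatter, and the furthest is compound 3, also beyond the scatter. Within the data shown here, no two of the measured compounds differ in only one place, so no step between measured compounds can be read from these data.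

Compound 4 `Clc1ccc2c(NCCCCCCCCNc3ccnc(Cl)n3)ccnc2c1` has not yet been measured in this assay. It differs from compound 2 in a single place: 2-chloropyrimidin-4-yl in place of 4-chloropyrimidin-2-yl on an amine nitrogen. The two have the same atoms, joined differently, and the change is confined to the group on the amine nitrogen whose other neighbours are a saturated chain carbon. Among the measured compounds shown here, with no measured pair of this kind to lean on, the step from compound 2 to compound 4 is expected to stay within the scatter, in either direction, as a 1.1-fold higher number from compound 2 to compound 4 (0.05 log units; within the scatter). Compound 4 is therefore estimated at 100 nM, with a range from 40 nM to 250 nM.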

Compound 4, solubility: 80 nM
Compound 4: middle estimate off by 1.3-fold (0.10 log units), on the high side, within the range that was stated.
By their numbers in this assay, from the lowest: compounds 4 and 2 (each within the scatter of the next); then compounds 1 and 3 (each within the scatter of the next).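

The swap gives the study its first readable step: in this assay, putting 2-chloropyrimidin-4-yl in place of 4-chloropyrimidin-2-yl on an amine nitrogen whose other neighbours are a saturated chain carbon gives a 1.1-fold lower number from compound 2 to compound 4 (0.05 log units; within the scatter). For this one pair, then, the way the same atoms are joined in this group does not separate the two compounds beyond the scatter, a result that compounds 1, 2 and 3 alone could not show. Nothing in the data accounts for this result.

Steps from these two compounds to compound 1 or compound 3 cannot be read, since they differ in more than one place. As far as these compounds go, whether the same swap stays within the scatter on a longer chain, or with a morpholine or a primary amine in place of the chlorine, remains open.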